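The source may hold more compounds than are shown below. What is called first, only, known or untested is meant among the compounds shown, and "the series" means these compounds.

Measured so far:
Compound 1 `O=C(/C=C/c1ccc(/C=N/NC(=O)c2ccncc2)cc1)c1ccc(F)cc1` gives 51.1%.
Compound 2 `Cc1ccc(C(=O)/C=C/c2ccc(/C=N/NC(=N)N)cc2)cc1` gives 77.7%.
Compound 3 `COc1ccc(C(=O)/C=C/c2ccc(/C=N/NC(=N)N)cc2)cc1` gives 57.2%.

All three numbers come from a functional assay on the whole organism (Ear) for inhibition, with Mus musculus as the target, with a stated time of 30 min, at a dose of 100 mg/kg by the intraperitoneal route; on this read-out lower numbers stand for less inhibition and higher numbers for more inhibition at the one dose given (going by the name of the read-out). Compound 1 holds the lowest of the three numbers; compound 3 stands within the scatter of compound 1, while compound 2 lies beyond the scatter above compound 1.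

The next step goes from compound 1 to compound 4 `O=C(N/N=C/c1ccc(/C=C/C(=O)c2ccc(Cl)cc2Cl)cc1)c1ccncc1`: 2,4-dichlorophenyl in place of 4-fluorophenyl on a carbonyl carbon. Among the measured compounds shown here, the one single-point step measured so far, a number 20.5 percentage points lower from compound 2 to compound 3 (beyond the scatter), changes a group on the ring that stands on the carbonyl carbon, so it sits in the same part of the shared core, but it swaps methoxy for methyl, neither of which leaves or enters here. For the measured compounds named here, no measured step covers chlorine in place of fluorine, nor a second halogen on that ring. The data therefore give no direction for the change, and the expected step is a number 3.9 percentage points higher from compound 1 to compound 4 (within the scatter), which is expected to stay inside the scatter. Compound 4 is estimated at 55%, with a range from 35% to 75%.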

Compound 4, a percentage reported as inhibition, in the whole organism at one dose (the size of the read-out at that dose, not a potency): 83.8%
Estimate against measurement, compound 4: 28.8 percentage points below; measured number outside the range, above it.
By their numbers in this assay, from the lowest: compounds 1 and 3 (each within the scatter of the next); then compounds 2 and 4 (each within the scatter of the next).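

In this assay, 2,4-dichlorophenyl in place of 4-fluorophenyl on a carbonyl carbon gives a number 32.7 percentage points higher from compound 1 to compound 4 (beyond the scatter), the first step showing that this exchange of one halogenated phenyl for another can move the read-out well beyond the scatter. Alongside a number 20.5 percentage points lower from compound 2 to compound 3 (beyond the scatter), which also changes a group on the ring on the carbonyl carbon, it shows steps in both directions from changes at this ring, though the two steps stand on different remainders of the molecule and cannot be set against each other as one trend. Nothing available explains the size or direction of this step.

This single step changes both the kind and the number of halogens, so their contributions remain inseparable. As far as these compounds go, how an unsubstituted phenyl, or a phenyl carrying an amine or a carboxylic acid, would behave on that carbonyl carbon also remains open.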